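Replacing the Piperazine Tail of Compound 3 with Dimethylamino

The source may hold more compounds than are shown below. What is called first, only, known or untested is meant among the compounds shown, and "the series" means these compounds.

For the measured compounds named here, compound 3 `O=C1c2c[n+]([O-])c3ccccc3c2C(=O)c2c1c1ccccc1n2CCCCN1CCNCC1` gives 12000 nM in a functional assay on MCF7 cells (Homo sapiens) for cytotoxicity, read by MTT assay, with a stated time of 72 h (a higher number here means a weaker inhibitor, a lower number a stronger inhibitor), the highest of the three numbers measured so far. Compound 1 `O=C1c2c[n+]([O-])c3ccccc3c2C(=O)c2c1c1ccccc1n2Cc1cn(CC(O)CO)nn1` gives 1110 nM in this assay, and compound 2 `O=C1c2c[n+]([O-])c3ccccc3c2C(=O)c2c1c1ccccc1n2CCCCN1CCCCC1` gives 150 nM. Both steps toward compound 3 lie beyond the scatter: an 11-fold higher number from compound 1 to compound 3 (1.03 log units; beyond the scatter) and an 80-fold higher number from compound 2 to compound 3 (1.90 log units; beyond the scatter). Compound 4 `CN(C)CCCCn1c2c(c3ccccc31)C(=O)c1c[n+]([O-])c3ccccc3c1C2=O` has not yet been measured; its change from compound 3 is dimethylamino in place of piperazin-1-yl on a saturated chain carbon, four bonds along the chain from an aromatic nitrogen. The step that bears most directly on this change is an 80-fold higher number from compound 2 to compound 3 (1.90 log units; beyond the scatter), in which the same piperazin-1-yl entered at the same place on the chain and the number rose sharply. Compound 4 undoes that entry with a tertiary amine that, like piperidin-1-yl, carries no hydrogen-bond donor, so a large step downward is expected, a 40-fold lower number from compound 3 to compound 4 (1.60 log units; beyond the scatter), landing in the region of compound 2 rather than compound 1. Compound 4 is therefore estimated at 300 nM in this assay, with a range from 80 nM to 1500 nM.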

Compound 4, half-maximal inhibitory concentration: 220 nM
Compound 4: middle estimate off by 1.4-fold (0.13 log units), on the high side; measured number inside the range.
By their numbers in this assay, from the lowest: compounds 2 and 4 (each within the scatter of the next); then compound 1; then compound 3.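

In this assay dimethylamino in place of piperazin-1-yl gives a 55-fold lower number from compound 3 to compound 4 (1.74 log units; beyond the scatter) on this chain, so a ring at this place is not required for a low number. Dimethylamino and piperidin-1-yl cannot be told apart here, with a 1.5-fold higher number from compound 2 to compound 4 (0.17 log units; within the scatter) lying within the scatter, and among the tails on this chain only piperazin-1-yl stands out with a high number. Compared with the 1-(2,3-dihydroxypropyl)-1H-1,2,3-triazol-4-yl side chain, the dimethylamino chain also gives a 5.0-fold lower number from compound 1 to compound 4 (0.70 log units; beyond the scatter) and so stands with compound 2 rather than compound 3.

No evidence is available on why piperazin-1-yl stands apart from the other two tails. Going by these compounds, it remains open whether 4-methylpiperazin-1-yl, morpholin-4-yl or a primary amine on this chain, or dimethylamino on a shorter or longer chain, would fall with compound 3 or with compound 4.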